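The source may report more compounds than this note shows. Statements on the series, on what has been measured and on what is new or still open speak of the compounds shown alone.

Compound 1 `CNC(=O)C#Cc1ccc(NC(=O)Nc2ccc(Cl)c(C(F)(F)F)c2)cc1`: 26400 nM
Compound 2 `CNC(=O)/C(C)=C/c1ccc(NC(=O)Nc2ccc(Cl)c(C(F)(F)F)c2)cc1`: > 50000 nM
Compound 3 `O=C(/C=C/c1ccc(NC(=O)Nc2ccc(Cl)c(C(F)(F)F)c2)cc1)NC1CCC1`: 4530 nM

All three share one core and differ only in the group on one aromatic carbon. In a functional assay on MX1 cells (Homo sapiens) for inhibition, read by MTT assay, with a stated time of 120 h (on this read-out higher numbers stand for weaker inhibition and lower numbers for stronger inhibition), compound 1 gives 26400 nM. For compound 2 the result is a limit of the assay, > 50000 nM (the limit of > 50000 nM in this assay, at which 1 of the 3 values shown sits). Compound 3 gives 4530 nM and stands lowest of the two numbers; the step of a 5.8-fold lower number from compound 1 to compound 3 (0.77 log units; beyond the scatter) shows how far compound 1 sits from it, and the step of an at least 11-fold lower number from compound 2 to compound 3 (1.04 log units; beyond the scatter) is larger still.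

Compound 4 `CNC(=O)CCc1ccc(NC(=O)Nc2ccc(Cl)c(C(F)(F)F)c2)cc1` is not yet measured. (2-(methylcarbamoyl)ethyl in place of 2-(cyclobutylcarbamoyl)ethenyl on an aromatic carbon). The cyclobutyl amide and the unsaturated linker both go. Within the data shown here, the steps that bear on this are a 5.8-fold lower number from compound 1 to compound 3 (0.77 log units; beyond the scatter), where the cyclobutyl amide on an ethenyl linker gave the lower number, and an at least 11-fold lower number from compound 2 to compound 3 (1.04 log units; beyond the scatter). Both point the same way, so undoing that group is expected to raise the number; the expected step is a 4.0-fold higher number from compound 3 to compound 4 (0.60 log units; beyond the scatter). Compound 4 is therefore estimated at 18000 nM, within 5000 nM to 50000 nM, with some chance that only a limit is reported.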

Compound 4, half-maximal inhibitory concentration: 20400 nM
Compound 4: the middle estimate sits 1.1-fold (0.05 log units) below what was measured; measured number inside the range.
By their numbers in this assay, from the lowest: compound 3; then compounds 4 and 1 (each within the scatter of the next). At a limit, above all of these: compound 2.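

With the methyl amide kept, the saturated 2-(methylcarbamoyl)ethyl chain and the ethynyl linker cannot be told apart in this assay, with a 1.3-fold lower number from compound 1 to compound 4 (0.11 log units; within the scatter), so at this position a triple bond in the linker is not needed for this level of inhibition. The methyl amide on the prop-1-en-1-yl linker stands apart, with an at least 2.4-fold lower number from compound 2 to compound 4 (0.38 log units; beyond the scatter), and that step is only a floor: the limit of > 50000 nM in this assay, at which 1 of the 4 values shown sits. Only compound 3 stays clearly lower, with a 4.5-fold higher number from compound 3 to compound 4 (0.65 log units; beyond the scatter), but that step changes the amide and the linker together, so it cannot be divided between them.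

The compounds shown do not separate these two changes, which would take a methyl amide on the ethenyl linker or a cyclobutyl amide on the saturated chain. Also open, from the compounds shown here alone, is how a carboxylic acid, a primary amide or a longer chain would behave at this position.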